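Notes on the series: compound 2 to compound 3

This account rests on a few compounds, and the source may have more. Where it says the series, first, only, none or still open, it means among the compounds named here.

In a physicochemical assay, read by spectrophotometry, with a stated time of 30 min (a higher number here means a weaker inhibitor, a lower number a stronger inhibitor), compound 1 (`O=C(CCc1nc2ccccc2c(=O)[nH]1)N/N=C/c1ccc(O)c(O)c1`) gives 113000000 nM and compound 2 (`O=C(CCCc1nc2ccccc2c(=O)[nH]1)N/N=C/c1cc(O)c(O)c(O)c1`) gives 78000000 nM and these two values lie within the scatter of each other. Among the compounds with values here, compound 2 therefore stands level with the only other measured compound. Compound 3 (`COc1cc(/C=N/NC(=O)CCCc2nc3ccccc3c(=O)[nH]2)ccc1O`) has not yet been measured. It carries 4-hydroxy-3-methoxyphenyl in place of 3,4,5-trihydroxyphenyl on a carbon with a double bond to nitrogen. Within the data shown here, no measured step is available to size this change, so the expectation is a judgement from the structural change and from compound 2 at 78000000 nM alone. A modest step beyond the scatter towards a higher number in this assay is expected, which would mean a weaker inhibitor. The expected move is a 2.4-fold higher number from compound 2 to compound 3 (0.39 log units; beyond the scatter) as an estimate with wide uncertainty. Compound 3 is estimated at 190000000 nM within a range from 70000000 nM to 550000000 nM as the expected reading.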

Compound 3, half-maximal inhibitory concentration: 236000000 nM
Estimate against measurement, compound 3: 1.2-fold (0.09 log units) below; the range from low to high includes it.
By their numbers in this assay, from the lowest: compounds 2 and 1 (each within the scatter of the next); then compound 3.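

In this assay, within the data shown here, 4-hydroxy-3-methoxyphenyl in place of 3,4,5-trihydroxyphenyl on a carbon with a double bond to nitrogen gives a 3.0-fold higher number from compound 2 to compound 3 (0.48 log units; beyond the scatter), the first measured step at this position, and it points to a weaker inhibitor. The position therefore responds to a change of aryl substituents, even though the heavy-atom count stays at 9 and the entering group has 1 hydrogen-bond donor against 3 in the group it replaces. No measurement available here explains the shift.

This single step cannot separate the loss of hydroxyl groups from the gain of the methoxy group. On these data alone, whether an amine or a carboxylic acid on the phenyl ring would move the number in either direction remains open, as does the effect of a longer chain with the aryl group held constant.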